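The source may hold more compounds than are shown below. What is called first, only, known or untested is meant among the compounds shown, and "the series" means these compounds.

Measured so far:
compound 1 `Cc1[nH]c2ccccc2c1C(=O)/C(C#N)=C/C=C(\Cl)c1ccc(Br)cc1`: 15.8%
compound 2 `N#C/C(=C\C=C(/Cl)c1ccc(Br)cc1)C(=O)c1c[nH]c2ccc(Br)cc12`: 15.8%

Both values come from a functional assay for inhibition, with a stated time of 30 min, tested at 1 mM; on this read-out lower numbers stand for less inhibition and higher numbers for more inhibition at the one concentration tested (going by the name of the read-out). In this assay compound 1 gives 15.8% and compound 2 gives 15.8%. Compound 2 stands level with compound 1 at the digits shown; the two values lie within the usual scatter of each other, so no order between them can be stated. Among the compounds with values here, no pair of measured compounds differing in a single place is available, and the series therefore shows nothing yet about how any one change moves this read-out.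

Compound 3 `N#C/C(=C\C=C(/Cl)c1ccc(Br)cc1)C(=O)c1c[nH]c2ccccc12` is next to be measured. It differs from compound 2 in one place:
hydrogen in place of bromo on an aromatic carbon
Within the data shown here, with no comparable step on record, the expectation rests on the flat picture given by compounds 1 and 2: no move beyond the scatter in this assay is expected, in either direction. The change is expected to be a number 0.8 percentage points lower from compound 2 to compound 3 (within the scatter). Compound 3 is expected to give 15%, with a range from 4% to 30%.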

Compound 3, a percentage reported as inhibition, at one concentration (the size of the read-out at that concentration, not a potency): 18.4%
Estimate against measurement, compound 3: 3.4 percentage points below; the measured number falls inside the stated range.
By their numbers in this assay, from the lowest: compounds 1, 2 and 3 (each within the scatter of the next).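

In this assay, hydrogen in place of bromo on this aromatic carbon gives a number 2.6 percentage points higher from compound 2 to compound 3 (within the scatter), so the read-out does not separate the two substituents at this position. Hydrogen in place of methyl on an aromatic carbon gives a number 2.6 percentage points higher from compound 1 to compound 3 (within the scatter), so neither bromo nor methyl has a step beyond the scatter when set against hydrogen in compound 3. No measurement at hand bears on the small size of these steps.

From the compounds shown here alone, whether a group of a different kind on this aromatic carbon, such as an amine or a carboxylic acid, would move the read-out beyond the scatter remains open, as does the effect of a longer chain in place of methyl. The read-out, taken at one concentration, also leaves any difference in potency among these compounds open.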